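Compound 4 in the cytotoxicity assay: an estimate

A few compounds are considered here, and "the series" means these few. Any claim that something is new, unique, unknown or untested is made for them only; others in the source may bear on it.

The three compounds measured so far, all sharing one core, are:
compound 1 `Cc1cc(=O)n(-c2ccccc2OC(F)(F)F)nc1C(=O)Nc1ccc(Oc2ncnc3[nH]ccc23)cc1`, which in a functional assay on HepG2 cells (Homo sapiens) for cytotoxicity, read by MTT assay, with a stated time of 72 h (on this read-out lower numbers stand for stronger inhibition and higher numbers for weaker inhibition), gives 22800 nM;
compound 2 `Cc1cc(=O)n(-c2ccc(F)cc2)nc1C(=O)Nc1ccc(Oc2ncnc3[nH]ccc23)c(F)c1`, which in this assay gives 12900 nM;
compound 3 `Cc1ccc(-n2nc(C(=O)Nc3ccc(Oc4ncnc5[nH]ccc45)c(F)c3)c(C)cc2=O)cc1`, which in this assay gives 18800 nM.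

Compound 3 sits second highest of these three numbers, but every gap among them is within the usual scatter, so no order can be read from them. Among the compounds with values here, the one step that is characterised is a 1.5-fold higher number from compound 2 to compound 3 (0.16 log units; within the scatter), a change on the same aryl ring that is now altered again. Compound 4 `Cc1cc(=O)n(-c2ccccc2OC(F)(F)F)nc1C(=O)Nc1ccc(Oc2ncnc3[nH]ccc23)c(F)c1` carries 2-(trifluoromethoxy)phenyl in place of 4-methylphenyl on an aromatic nitrogen. Compound 4 thereby bears the same aryl group as compound 1, differing from it only in the fluoro on the amide-bearing ring, which compound 2 and compound 3 also carry; their numbers show no move beyond the scatter relative to compound 1. Hence compound 4 is expected to stay close to compound 3, with the estimated step of a 1.1-fold higher number from compound 3 to compound 4 (0.03 log units; within the scatter) not exceeding the scatter. The estimate for compound 4 in this assay is 20000 nM, within 8000 nM to 50000 nM.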

Compound 4, half-maximal inhibitory concentration: > 60000 nM
Compound 4 was reported as a limit; the forecaster's own chance of this, stated with the estimate: 10%; middle value at least 3.0-fold (0.47 log units) away from the limit.
By their numbers in this assay, from the lowest: compounds 2, 3 and 1 (each within the scatter of the next). At a limit, above all of these: compound 4.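

Compound 4 is reported only as a limit, not as a number: the limit of > 60000 nM in this assay, at which 1 of the 4 values shown sits.

The aryl group on the aromatic nitrogen can clearly shift this read-out: changing it gives an at least 3.1-fold higher number from compound 3 to compound 4 (0.50 log units; beyond the scatter) and an at least 4.6-fold higher number from compound 2 to compound 4 (0.66 log units; beyond the scatter), whereas the earlier change on this ring gave only a 1.5-fold higher number from compound 2 to compound 3 (0.16 log units; within the scatter). The fluoro on the amide-bearing ring also counts when the 2-(trifluoromethoxy)phenyl group is present, giving an at least 2.6-fold higher number from compound 1 to compound 4 (0.42 log units; beyond the scatter), and on this read-out all three higher numbers stand for weaker inhibition.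

From the compounds shown here alone, how far compound 4 lies past its limit stays open, so the full size of these steps is unknown. Also open, going by these compounds, is whether a phenyl ring carrying a methoxy group or an amine in place of trifluoromethoxy would give a similar shift, and why the shift arises.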